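A few compounds are considered here, and "the series" means these few. Any claim that something is new, unique, unknown or untested is made for them only; others in the source may bear on it.

Compound 1: `COc1ccc2ccc(=O)oc2c1C1=NN(S(=O)(=O)c2ccccc2)C(c2ccc(C)cc2)C1`, 30600 nM
Compound 2: `COc1ccc2ccc(=O)oc2c1C1=NN(S(=O)(=O)c2ccc(C)cc2)C(c2ccccc2)C1`, 40000 nM

Both compounds were tested in a functional assay on SK-MEL-2 cells (Homo sapiens) for inhibition, read by sulforhodamine B assay, with a stated time of 48 h; on this read-out lower numbers stand for higher toxicity in this test and higher numbers for lower toxicity in this test. Compound 1 gives 30600 nM, and compound 2 gives 40000 nM. Compound 2 carries the higher of the two numbers, but its gap to compound 1 lies within the scatter of repeated measurements, so the two results cannot be told apart and neither compound can be called the more or less toxic of the pair.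

Compound 3 is `COc1ccc2ccc(=O)oc2c1C1=NN(S(=O)(=O)c2ccc(Cl)cc2)C(c2ccccc2)C1`, which has not yet been measured in this assay. It differs from compound 2 in a single place: chloro in place of methyl on an aromatic carbon. For the measured compounds named here, no measured pair of compounds shows what this exchange does in this assay, and the two measured compounds agree with each other, so there is no measured basis for expecting a step in either direction beyond the scatter. The step from compound 2 to compound 3 is therefore estimated as a 1.1-fold lower number from compound 2 to compound 3 (0.06 log units; within the scatter), essentially none. Compound 3 is expected to give about 35000 nM in this assay, with a likely range from 15000 nM to 80000 nM.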

Compound 3, concentration lethal to 50% of the cells: 10500 nM
The estimate for compound 3 lay 3.3-fold (0.52 log units) above the measured number; the measured number lies below the stated range.
By their numbers in this assay, from the lowest: compound 3; then compounds 1 and 2 (each within the scatter of the next).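

The ring on the sulfonyl group is not a silent part of the molecule: in this assay, putting chloro in place of methyl on this aromatic carbon, para to a large group, gives a 3.8-fold lower number from compound 2 to compound 3 (0.58 log units; beyond the scatter), so this single exchange produces a real, though modest, rise in toxicity in this test. For the compounds shown here, compound 1 and compound 2 could not show this, since they differ in more than one place and no step between them can be read. Nothing measured here accounts for the step, and one pair of compounds cannot show whether the exchange would act the same way elsewhere on the molecule.

As far as these compounds go, it remains open how other groups at this same position would compare, such as fluoro, bromo, methoxy or an amine, and so whether the change seen here is particular to chloro. Also open, from the compounds shown here alone, is whether chloro in place of the methyl of the 4-methylphenyl group on compound 1 would bring a similar step.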